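The compounds below may be only part of what the source reports. "The series", "measured", "known", "first", "only" and "open" are said of these compounds alone.

Compound 1 `CN(C)C(=O)c1cc2cnc(Nc3ccc(S(=O)(=O)NCCCCCN=C=S)cc3)nc2n1C1CCCC1` and compound 2 `CN(C)C(=O)c1cc2cnc(Nc3ccc(S(=O)(=O)NCCCCCCN=C=S)cc3)nc2n1C1CCCC1` share one core and differ only in the saturated chain carried by the sulfonamide nitrogen. In a functional assay on A549 cells (Homo sapiens) for inhibition, read by CCK-8 assay, with a stated time of 72 h, tested at 10 uM (on this read-out lower numbers stand for a weaker effect and higher numbers for a stronger effect at the one concentration tested), compound 1 gives 102%, the higher of the two numbers recorded, and compound 2 gives 101%; the step of a number 1 percentage points lower from compound 1 to compound 2 (within the scatter) is within the scatter, so lengthening the chain by one carbon changes nothing that can be seen at this concentration.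

Compound 3 `CN(C)C(=O)c1cc2cnc(Nc3ccc(NC(=O)CCCCCN=C=S)cc3)nc2n1C1CCCC1` keeps the core and the terminal part of the chain but alters the link on the aromatic carbon of the six-membered aromatic ring of carbon only, para to a large group: a group of 11 heavy atoms (7 carbon, 2 nitrogen, 1 oxygen, 1 sulfur; no ring) in place of a group of 12 heavy atoms (6 carbon, 2 nitrogen, 2 oxygen, 2 sulfur; no ring), on an aromatic carbon. Within the data shown here, no measured step covers this exchange; the only step available concerns chain length and lies within the scatter. With both measured compounds near the ceiling of the read-out, compound 3 is expected to stay in that region, with a step of a number 7 percentage points lower from compound 1 to compound 3 (within the scatter) that need not exceed the scatter. The estimate for compound 3 in this assay is therefore 95%, within 78% to 104%.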

Compound 3, a percentage reported as inhibition, at one concentration (the size of the read-out at that concentration, not a potency): 100%
The estimate for compound 3 lay 5 percentage points below the measured number; the measured number falls inside the stated range.
By their numbers in this assay, from the lowest: compounds 3, 2 and 1 (each within the scatter of the next).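

In this assay, the exchange on an aromatic carbon of the six-membered aromatic ring of carbon only, para to a large group, gives a number 2 percentage points lower from compound 1 to compound 3 (within the scatter). This position therefore accepts the group of 11 heavy atoms in place of the group of 12 heavy atoms with no difference that can be read at this single concentration, so the sulfonamide link of compound 1 is not required for a number near the top of the read-out. No evidence on the reason for this result is at hand.

With compound 1, compound 2 and compound 3 all near the ceiling, any difference in potency among them remains unresolved. Also open, going by these compounds, is how a terminal amine or a carboxylic acid at the end of the chain would read on this core.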